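Cytotoxicity notes on the series, compound 3 to compound 4

A few compounds are considered here, and "the series" means these few. Any claim that something is new, unique, unknown or untested is made for them only; others in the source may bear on it.

Measured so far in an ADME assay on BJ cells (Homo sapiens) for cytotoxicity, with a stated time of 72 h; on this read-out lower numbers stand for an effect already at smaller amounts and higher numbers for an effect only at larger amounts of compound:
compound 1, `Nc1nc(-c2ccccn2)nn1-c1ncnc2cc(OC(F)(F)F)ccc12`, a limit of > 13000 nM
compound 2, `COc1cc2ncnc(Nc3ccccn3)c2cc1OC`, a limit of > 27000 nM
compound 3, `COc1cc2ncnc(-n3nc(-c4ccccn4)nc3N)c2cc1OCCCN1CC(C)OC(C)C1`, a limit of > 25000 nM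

Each of these three values is a limit of the assay and not a number. Compound 1 sits at the limit of > 13000 nM in this assay, at which 1 of the 3 values shown sits. Compound 3 sits at the limit of > 25000 nM in this assay, at which 1 of the 3 values shown sits. Compound 2 sits at the limit of > 27000 nM in this assay, at which 1 of the 3 values shown sits. Compound 3 therefore stands at a limit, as do the other two values shown, so no ordering among them can be read.

Compound 4, `COc1cc2ncnc(-n3nc(-c4ccccn4)nc3N)c2cc1OCCCNC(=O)OCC(F)(F)F`, differs from compound 3 by ((2,2,2-trifluoroethoxy)carbonyl)amino in place of 2,6-dimethylmorpholin-4-yl on a saturated chain carbon, three bonds along the chain from an oxygen on an aromatic ring. Within the data shown here, no step between measured compounds is known for this assay. In this assay the change from compound 3 to compound 4 is expected to give no step beyond the scatter, a number no higher from compound 3 to compound 4 (the limit leaves the size open). Compound 4 is estimated at 25000 nM, within 10000 nM to 60000 nM, most likely again reported as a limit.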

Compound 4, half-maximal effective concentration: > 11000 nM
Compound 4: no number, only a limit; the forecaster's own chance of this, stated with the estimate: 80%; the middle value is on the limit's open side.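

No step can be read from compound 3 to compound 4: both values are limits of the assay, not numbers. The compounds shown leave open at what concentration any of them takes effect, and whether exchanging 2,6-dimethylmorpholin-4-yl for ((2,2,2-trifluoroethoxy)carbonyl)amino alters it.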